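An Amide Swap at the Limit of a Glutamate Receptor Assay

This account rests on a few compounds, and the source may have more. Where it says the series, first, only, none or still open, it means among the compounds named here.

Three compounds sharing one core were tested in an assay on HEK293 cells for negative allosteric modulation of metabotropic glutamate receptor 5 (Homo sapiens), read by FLIPR, with a stated time of 1 h; a lower number here means a stronger inhibitor, a higher number a weaker inhibitor. Compound 1 `CN1CCc2nc(C#Cc3ccccc3)sc2C1` carries a methyl on the ring amine nitrogen. In this assay compound 1 reaches only the limit > 10000 nM, which is a limit and not a number. Compound 2 `CCN1CCc2nc(C#Cc3ccccc3)sc2C1` carries an ethyl there instead, and in this assay compound 2 gives 1200 nM. That change produced an at least 8.3-fold lower number from compound 1 to compound 2 (0.92 log units; beyond the scatter). Compound 3 `CC1CC1C(=O)N1CCc2nc(C#Cc3ccccc3)sc2C1` carries a (2-methylcyclopropyl)carbonyl on that nitrogen. In this assay compound 3 stands at the limit > 10000 nM, again a limit rather than a number. Going from the ethyl gave an at least 8.3-fold higher number from compound 2 to compound 3 (0.92 log units; beyond the scatter), while the step that the two limits leave unreadable from compound 1 to compound 3 cannot be read because both ends sit at the limit of > 10000 nM in this assay, at which 2 of the 3 values shown sit.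

Compound 4 `O=C(C1CCC(F)(F)CC1)N1CCc2nc(C#Cc3ccccc3)sc2C1` differs from compound 3 by 4,4-difluorocyclohexyl in place of 2-methylcyclopropyl on a carbonyl carbon. Among the compounds with values here, no measured step exchanges one group on the carbonyl carbon for another, so none bears directly on this change; the figures show only that compound 3 sits at the limit. Compound 4 is therefore expected to remain near that limit, with an estimated step that the limit leaves unreadable from compound 3 to compound 4. The expected value for compound 4 is 15000 nM, with a range from 3000 nM to 50000 nM.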

Compound 4, half-maximal inhibitory concentration: > 10000 nM
Compound 4: no number, only a limit; the forecaster's own chance of this, stated with the estimate: 70%; the middle value is on the limit's open side.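

Compound 3 and compound 4 both stop at a limit of the assay rather than a number, so the step between them cannot be read: the limit of > 10000 nM in this assay, at which 3 of the 4 values shown sit.

Going by these compounds, what stays open is how 4,4-difluorocyclohexyl and 2-methylcyclopropyl on the carbonyl carbon truly compare in this assay.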